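Swapping the Thiophene for Iodine on a Nucleoside Core

The compounds below may be only part of what the source reports. "The series", "measured", "known", "first", "only" and "open" are said of these compounds alone.

Compound 1, `COc1ncnc2c1c(-c1ccsc1)cn2[C@@H]1O[C@H](CO)[C@@H](O)[C@H]1O`: in a functional assay on CCRF-CEM cells (Homo sapiens), read by MTT assay, with a stated time of 72 h (a higher number here means a weaker inhibitor, a lower number a stronger inhibitor), compound 1 gives 2570 nM.
Compound 2, `COc1nc(N)nc2c1c(-c1ccsc1)cn2[C@@H]1O[C@H](CO)[C@@H](O)[C@H]1O`: in this assay compound 2 reaches only a limit of the assay, > 20000 nM.
Compound 3, `Cc1ncnc2c1c(-c1ccsc1)cn2[C@@H]1O[C@H](CO)[C@@H](O)[C@H]1O`: in this assay compound 3 gives 11200 nM.

Among these, compound 1 stands lowest of the two numbers, and so is the strongest inhibitor here. Its nearest neighbour is compound 3, with a 4.4-fold higher number from compound 1 to compound 3 (0.64 log units; beyond the scatter). Compound 2 sits at the limit described as the limit of > 20000 nM in this assay, at which 1 of the 3 values shown sits. The other measured step is an at least 7.7-fold higher number from compound 1 to compound 2 (0.89 log units; beyond the scatter). Both of these steps alter the shared core at a place away from the thiophen-3-yl group and leave that group untouched.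

Compound 4, `COc1ncnc2c1c(I)cn2[C@@H]1O[C@H](CO)[C@@H](O)[C@H]1O`, differs from compound 1 in just one way: iodo in place of thiophen-3-yl on an aromatic carbon. For the measured compounds named here, no measured step touches this position, so the two steps above say nothing directly about the size or direction of this change. A large ring group is exchanged for a single atom, and on that basis a weaker inhibitor is expected, roughly a 2.7-fold higher number from compound 1 to compound 4 (0.44 log units; beyond the scatter). The estimate for compound 4 in this assay is 7000 nM, likely between 1500 nM and 25000 nM.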

Compound 4, half-maximal inhibitory concentration: 1150 nM
Compound 4: the middle estimate sits 6.1-fold (0.78 log units) above what was measured; the whole stated range lies above it.
By their numbers in this assay, from the lowest: compound 4; then compound 1; then compound 3. At a limit, above all of these: compound 2.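

For the compounds shown here, until now, both measured steps left the thiophen-3-yl group in place and raised the number, whereas iodo in place of thiophen-3-yl on this aromatic carbon is the first change to lower it, with a 2.2-fold lower number from compound 1 to compound 4 (0.35 log units; beyond the scatter). In this assay, then, keeping a five-membered aromatic ring at this position is not needed to hold the activity of compound 1, since a single iodine atom, which brings no ring and no hydrogen-bond acceptor, gives a lower number rather than a higher one. Nothing measured about either group bears on this result, and the compounds shown offer no explanation for it.

As far as these compounds go, with only these two groups compared at this position, it remains open how a bromo group, a chloro group, a plain hydrogen or a phenyl ring would compare with iodo and thiophen-3-yl. Also open, from the compounds shown here alone, is whether iodo would lower the number in the same way on the core of compound 3, which carries methyl in place of methoxy, or on the core of compound 2, which carries the added amino group.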